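Chloro for Bromo: An Expectation for Compound 4

The source may hold more compounds than are shown below. What is called first, only, known or untested is meant among the compounds shown, and "the series" means these compounds.

The three measured compounds, with their results in an ADME assay on MT4 cells (Homo sapiens) for cytotoxicity, read by MTT assay, with a stated time of 4 days; a lower number here means that less compound is tolerated, a higher number that more compound is tolerated:

Compound 1, `O=C(COc1cccc2ccccc12)N/N=C/c1cccc([N+](=O)[O-])c1`: 12.1 ug/mL
Compound 2, `O=C(COc1cccc2ccccc12)N/N=C/c1ccc(Cl)cc1`: 87.6 ug/mL
Compound 3, `O=C(COc1cccc2ccccc12)N/N=C/c1cccc(Br)c1`: 87.4 ug/mL

Compound 3 stands second highest of the three numbers. Its nearest neighbour is compound 2, with a 1.0-fold lower number from compound 2 to compound 3 (0.00 log units; within the scatter); its furthest is compound 1, with a 7.2-fold higher number from compound 1 to compound 3 (0.86 log units; beyond the scatter), a step that belongs to bromo in place of nitro on an aromatic carbon.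

Compound 4, `O=C(COc1cccc2ccccc12)N/N=C/c1cccc(Cl)c1`, has not yet been measured in this assay. It differs from compound 3 in one place: chloro in place of bromo on an aromatic carbon. The step that bears most directly on this change is the one between the two halogen-bearing compounds, which was within the scatter, while the larger step came from exchanging a nitro group and does not speak to a halogen swap. The expected step, a 1.0-fold lower number from compound 3 to compound 4 (0.01 log units; within the scatter), is therefore none beyond the scatter. Compound 4 is estimated to give 85 ug/mL in this assay, in a range from 45 ug/mL to 160 ug/mL.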

Compound 4, half-maximal cytotoxic concentration: 89.9 ug/mL
For compound 4 the middle estimate is 1.1-fold (0.02 log units) below the measured one; the range from low to high includes it.
By their numbers in this assay, from the lowest: compound 1; then compounds 3, 2 and 4 (each within the scatter of the next).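

In this assay, going by these compounds alone, the step from bromo to chloro on this aromatic carbon is a 1.0-fold higher number from compound 3 to compound 4 (0.01 log units; within the scatter) and so adds the first direct comparison of these two halogens at one place. The earlier halogen pair differed in both halogen and place, whereas the new pair with a shared chloro isolates the place and gives a 1.0-fold higher number from compound 2 to compound 4 (0.01 log units; within the scatter) as the step between 4-chlorophenyl and 3-chlorophenyl. Chloro in place of nitro gives a 7.4-fold higher number from compound 1 to compound 4 (0.87 log units; beyond the scatter) and thus matches the step already seen for bromo, leaving compound 1 apart from the three halogen-bearing compounds.

Going by these compounds, it remains open where an amine, a methoxy group or a carboxylic acid at this place would stand relative to compound 1 and the halogen-bearing compounds. Nothing available explains why the nitro compound differs from the others.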